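The source may report more compounds than this note shows. Statements on the series, on what has been measured and on what is new or still open speak of the compounds shown alone.

Working notes on the hydrazone series. Compound 1, drawn as `Cc1ncc([N+](=O)[O-])n1CC(=O)N/N=C/c1cccc(Cl)c1`, has no recorded result in an ADME assay on HepG2 cells (Homo sapiens) for cytotoxicity, read by MTT assay, with a stated time of 48 h; on this read-out higher numbers stand for weaker inhibition and lower numbers for stronger inhibition; its entry reads "not determined" (no result reported). Compound 2, drawn as `CCc1ccc(/C=N/NC(=O)Cn2c([N+](=O)[O-])cnc2C)cc1`, reaches only the assay limit in this assay , reported as > 100000 nM, so no single number stands for it; this is the boundary described by the limit of > 100000 nM in this assay, at which 1 of the 2 values shown sits. Compound 3, drawn as `Cc1ccc(/C=N/NC(=O)Cn2c([N+](=O)[O-])cnc2C)cc1`, remains to be measured. It differs from compound 2 by hydrogen in place of methyl on a saturated chain carbon bound to an aromatic carbon. Going by the values given here, with no measured step of this kind available, no shift beyond the scatter is expected, and the step from compound 2 to compound 3 is estimated at a number no higher from compound 2 to compound 3 (the limit leaves the size open). Compound 3 is therefore expected to sit near 100000 nM, within 50000 nM to 300000 nM, most likely again reported only as a limit.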

Compound 3, half-maximal inhibitory concentration: > 100000 nM
Compound 3 gave a limit, no number (the forecaster's own chance of this, stated with the estimate: 85%); the middle value lies on the limit itself.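

No step can be read between compound 2 and compound 3 in this assay, since each is reported only as a limit: the limit of > 100000 nM in this assay, at which 2 of the 3 values shown sit.

The compounds shown leave open whether going from ethyl to methyl changes the read-out at all.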